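A few compounds are considered here, and "the series" means these few. Any claim that something is new, unique, unknown or untested is made for them only; others in the source may bear on it.

Measured compounds, values in an assay for binding affinity to 5-hydroxytryptamine receptor 1B (Homo sapiens), read by radioligand binding; a higher number here means a weaker inhibitor, a lower number a stronger inhibitor:

compound 1 `CCCCCCCC(=O)Nc1ccc2[nH]cc(C3CCN(C)CC3)c2n1`: compound 1 gives 32 nM
compound 2 `CN1CCC(c2c[nH]c3ccc(NC(=O)C4CC4)nc23)CC1`: compound 2 gives 1700 nM
compound 3 `CN1CCC(c2c[nH]c3ccc(NC(=O)c4cccc(F)c4)nc23)CC1`: compound 3 gives 1600 nM

Compound 3 sits with compound 2 at the weak end of the set; the two differ only by a 1.1-fold lower number from compound 2 to compound 3 (0.03 log units; within the scatter), so nothing separates them. Compound 1 stands far apart: the change to compound 2 costs a 53-fold higher number from compound 1 to compound 2 (1.73 log units; beyond the scatter) and the change to compound 3 costs a 50-fold higher number from compound 1 to compound 3 (1.70 log units; beyond the scatter), both on the group attached to the carbonyl carbon.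

The next compound, compound 4 `Cc1cccc(C(=O)Nc2ccc3[nH]cc(C4CCN(C)CC4)c3n2)c1`, keeps the acyl aryl group of compound 3 and alters only one substituent on it: methyl in place of fluoro on an aromatic carbon.

Among the compounds with values here, no measured step in this set changes a substituent on that aryl ring, so there is no direct precedent. Within the data shown here, the only step that bears on it is a 1.1-fold lower number from compound 2 to compound 3 (0.03 log units; within the scatter), which shows that exchanging the whole group on the carbonyl carbon between a small aliphatic ring and the fluorinated aryl left the number unchanged. A single substituent exchange within that aryl is a smaller change than that, and the expectation is therefore no step beyond the scatter in this assay , expected as no change at the digits printed from compound 3 to compound 4 (within the scatter).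

Compound 4 is estimated at 1600 nM, with a range of 500 nM to 5000 nM.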

Compound 4, inhibition constant: 1200 nM
Beside the measured number, compound 4's estimate is 1.3-fold (0.12 log units) above it; the measured number falls inside the stated range.
By their numbers in this assay, from the lowest: compound 1; then compounds 4, 3 and 2 (each within the scatter of the next).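

In this assay, within the data shown here, the first exchange on the aryl ring itself gives a 1.3-fold lower number from compound 3 to compound 4 (0.12 log units; within the scatter), so at this place, on an aromatic carbon meta to a large group, methyl and fluoro cannot be told apart. The 3-methylphenyl group also reads level with cyclopropyl on the carbonyl carbon, with a 1.4-fold lower number from compound 2 to compound 4 (0.15 log units; within the scatter), while the gap to the heptyl compound persists, with a 38-fold higher number from compound 1 to compound 4 (1.57 log units; beyond the scatter), so compounds 2, 3 and 4 now form a group of three, with compound 1 the only one apart from them. No measurement shown here accounts for methyl and fluoro reading alike.

On these data alone, it remains open whether this ring tolerates any substituent at this place or only these two, and a methoxy, an amine or a carboxylic acid there would test that. Also open, as far as these compounds go, is how the number runs between cyclopropyl and heptyl on the carbonyl carbon, which a butyl or hexyl chain would address, and whether a longer chain carries the gain on its own.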